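This account rests on a few compounds, and the source may have more. Where it says the series, first, only, none or still open, it means among the compounds named here.

Compound 1 `O=C(Nc1nc(-c2cc3ccccc3o2)cs1)Nc1ccccc1F` gives 2630 nM; compound 3 `O=C(Nc1cccc(Cl)c1)Nc1nc(-c2cc3ccccc3o2)cs1` gives 14100 nM; compound 2 `O=C(Nc1cccc([N+](=O)[O-])c1)Nc1nc(-c2cc3cc(Br)ccc3o2)cs1` gives 159000 nM, all in a physicochemical assay, with a stated time of 6 min; on this read-out lower numbers stand for stronger inhibition and higher numbers for weaker inhibition.

Compound 2 thus shows the highest number of the three, well beyond the scatter from both compound 3 and compound 1. The unmeasured compound 4 `COc1cccc(NC(=O)Nc2nc(-c3cc4cc(Br)ccc4o3)cs2)c1` differs from compound 2 by methoxy in place of nitro on an aromatic carbon. Within the data shown here, the only step among the measured compounds, a 5.4-fold higher number from compound 1 to compound 3 (0.73 log units; beyond the scatter), changes a different group on the same kind of ring, so it bears on the present change only loosely, showing that substituents on that ring move this assay by modest amounts. Compound 4 is therefore expected to give 40000 nM, between 8000 nM and 200000 nM, a step of a 4.0-fold lower number from compound 2 to compound 4 (0.60 log units; beyond the scatter) that is uncertain in direction.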

Compound 4, half-maximal inhibitory concentration: > 200000 nM
Compound 4 ended at the assay's limit; the forecaster's own chance of this, stated with the estimate: 10%; middle value at least 5.0-fold (0.69 log units) away from the limit.
By their numbers in this assay, from the lowest: compound 1; then compound 3; then compound 2. At a limit, above all of these: compound 4.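

The value of compound 4 is a limit of this assay, not a number: the limit of > 200000 nM in this assay, at which 1 of the 4 values shown sits.

At this position, methoxy in place of nitro gives an at least 1.2-fold higher number from compound 2 to compound 4 (0.09 log units; that floor lies within the scatter), so the change brought no lower number, though the step does not establish a real rise. The 3-methoxyphenyl group therefore shows no sign of stronger inhibition than the 3-nitrophenyl group in this assay.

From the compounds shown here alone, how far compound 4 lies past the limit remains open. So does whether an amine or a carboxylic acid at this position would bring the number down.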